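The source may report more compounds than this note shows. Statements on the series, on what has been measured and on what is new or still open speak of the compounds shown alone.

Compound 1 `CC(=O)Nc1cccc(-c2cnc3[nH]cc(-c4ccncc4)c3c2)c1`: 9100 nM in a functional assay on MCF7 cells (Homo sapiens) for cytotoxicity, read by MTT assay, with a stated time of 48 h; a higher number here means a weaker inhibitor, a lower number a stronger inhibitor
Compound 2 `Cc1ccc(S(=O)(=O)Nc2cc(N)cc(-c3cnc4[nH]cc(-c5ccncc5)c4c3)c2)cc1`: 10400 nM in this assay
Compound 3 `Nc1cccc(-c2cnc3[nH]cc(-c4ccncc4)c3c2)c1`: 2300 nM in this assay

Of the three measured compounds, compound 3 gives the lowest number and is the strongest inhibitor, since its steps to the other two are both beyond the scatter: a 4.0-fold lower number from compound 1 to compound 3 (0.60 log units; beyond the scatter) and a 4.5-fold lower number from compound 2 to compound 3 (0.66 log units; beyond the scatter). Compound 4 `CNc1cccc(-c2cnc3[nH]cc(-c4ccncc4)c3c2)c1` is not yet measured. It differs from compound 3 by methyl in place of hydrogen on a nitrogen on an aromatic ring.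

The step from compound 1 to compound 3 alters the same nitrogen and so bears most directly on this change. Replacing acetyl with hydrogen gave a 4.0-fold lower number from compound 1 to compound 3 (0.60 log units; beyond the scatter). The step from compound 2 to compound 3 concerns a different position and bears only loosely. Since adding acetyl on this nitrogen raised the number by a modest amount, adding a methyl there is expected to move the number upward as well, though with no direct comparison for methyl the size is uncertain and may stay within the scatter. Compound 4 is therefore estimated at 3800 nM, with a range of 1500 nM to 9500 nM, which would mean an expected step of a 1.7-fold higher number from compound 3 to compound 4 (0.22 log units; within the scatter).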

Compound 4, half-maximal inhibitory concentration: 4500 nM
Compound 4: the middle estimate sits 1.2-fold (0.07 log units) below what was measured; low and high end bracket the measured number.
By their numbers in this assay, from the lowest: compounds 3 and 4 (each within the scatter of the next); then compounds 1 and 2 (each within the scatter of the next).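

In this assay, this nitrogen carries a methyl with no difference from the free amino group beyond the scatter (a 2.0-fold higher number from compound 3 to compound 4 (0.29 log units; within the scatter)), so the earlier rise on adding acetyl does not extend to every group placed there. Methyl and acetyl on the same nitrogen are separated by a modest step beyond the scatter (a 2.0-fold lower number from compound 1 to compound 4 (0.31 log units; beyond the scatter)), which shows that the identity of the added group matters at this position, not only the loss of the hydrogen. Nothing available explains the difference between these two groups.

The compounds shown leave open whether an ethyl, a longer chain or a second methyl on this nitrogen would stay within the scatter of compound 3. They also leave open how a sulfonamide on this nitrogen would compare with the acetyl of compound 1.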